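Acetyl esters of hydroxyalkyl purines: cytotoxicity working notes

This account rests on a few compounds, and the source may have more. Where it says the series, first, only, none or still open, it means among the compounds named here.

The series is followed in an ADME assay on L1210/0 cells (Mus musculus) for cytotoxicity, with a stated time of 48 h; on this read-out higher numbers stand for weaker inhibition and lower numbers for stronger inhibition. Compound 1 `CC(O)Cn1cnc2c(N)nc(I)nc21` carries a free hydroxyl on a short chain at the ring nitrogen. In this assay compound 1 reaches only the limit of > 200000 nM, which is a limit and not a number. Compound 2 `CC(=O)OC(C)Cn1cnc2c(N)nc(I)nc21` is its ester; the change from compound 1 to compound 2 is acetyl in place of hydrogen on an oxygen on a saturated carbon. In this assay compound 2 likewise stops at the limit of > 200000 nM. The step that the two limits leave unreadable from compound 1 to compound 2 therefore cannot be read, because the limit of > 200000 nM in this assay, at which 3 of the 3 values shown sit, leaves both ends unresolved.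

Compound 3 `Nc1nc(Cl)c2ncn(COCCO)c2n1` belongs to a different core; the difference between the core of compound 1 and the core of compound 3 is not broken down here. In this assay compound 3 also gives only the limit of > 200000 nM, a limit and not a number.

Compound 4 `CC(=O)OCCOCn1cnc2c(Cl)nc(N)nc21` has not yet been measured in this assay. Its relation to compound 3 is acetyl in place of hydrogen on an oxygen on a saturated carbon, the same change as that from compound 1 to compound 2, at the same kind of place. Among the measured compounds shown here, the measured pair gives no readable size for this change, and every compound so far sits at the limit. The step from compound 3 to compound 4 is expected to be a step that the limit leaves unreadable from compound 3 to compound 4, resting on the unreadable step that the two limits leave unreadable from compound 1 to compound 2 and on the limit of compound 3 at > 200000 nM. Compound 4 is accordingly estimated at 300000 nM, with a range from 100000 nM to 1000000 nM, and most probably only a limit will again be reported.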

Compound 4, half-maximal inhibitory concentration: > 200000 nM
Compound 4: a limit, no number; the forecaster's own chance of this, stated with the estimate: 85%; the middle value does not contradict the limit.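

No step can be read from compound 3 to compound 4, since both compounds stop at a limit and not at a number, because of what all the values share: the limit of > 200000 nM in this assay, at which 4 of the 4 values shown sit.

The compounds shown leave open whether acetyl in place of hydrogen on an oxygen on a saturated carbon changes the read-out in this assay at all, and whether either core gives a readable number there.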